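Solubility notes: 4-fluorobenzyl to 3-fluorobenzyl

The source may hold more compounds than are shown below. What is called first, only, known or untested is meant among the compounds shown, and "the series" means these compounds.

- compound 1 `CNC(=O)c1ccc(=O)n(Cc2cc(Br)ccc2F)c1`: limit, >= 143 ug/mL
- compound 2 `CNC(=O)c1cc(C(=O)NC2CC2)cn(Cc2ccc(F)cc2)c1=O`: limit, >= 162 ug/mL
- compound 3 `CCNC(=O)c1cc(C(=O)NC)c(=O)n(Cc2ccccc2)c1`: limit, >= 144 ug/mL

In a physicochemical assay for solubility (a higher number here means a more soluble compound, a lower number a less soluble compound), compound 2 gives >= 162 ug/mL, which is a limit of the assay and not a number. Compound 1 and compound 3 are also reported only as limits, so the three compounds cannot be ranked against one another, and compound 2 has no defined place among them.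

The next compound to be measured is compound 4 `CNC(=O)c1cc(C(=O)NC2CC2)cn(Cc2cccc(F)c2)c1=O`. It differs from compound 2 as follows: 3-fluorophenyl in place of 4-fluorophenyl on a saturated chain carbon bound to an aromatic nitrogen. In words, 3-fluorophenyl stands in place of 4-fluorophenyl on a saturated chain carbon bound to an aromatic nitrogen, and the two compounds have the same atoms, joined differently.

Among the compounds with values here, no measured pair shows a change of this kind, so the expectation rests on the structural change alone and on the limits seen so far. The expected change is an at least 1.0-fold lower number from compound 2 to compound 4 (0.00 log units; that floor lies within the scatter), with nothing beyond the scatter foreseen in this assay. For compound 4 the estimated value is 160 ug/mL, with an expected range of 80 ug/mL to 190 ug/mL. A report as a limit is again the likeliest form of the result.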

Compound 4, solubility: >= 133 ug/mL
Compound 4: only a limit was reported; the forecaster's own chance of this, stated with the estimate: 70%; the middle value lies beyond the limit too.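

In this assay compound 4 gives >= 133 ug/mL, which is a limit of the assay and not a number. Compound 2 is also reported only as a limit, so no step can be read between compound 2 and compound 4. The compounds shown leave open whether 3-fluorophenyl in place of 4-fluorophenyl changes the result in this assay at all.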